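Swapping a sulfur ring for an oxygen ring on two cores

The source may report more compounds than this note shows. Statements on the series, on what has been measured and on what is new or still open speak of the compounds shown alone.

Compound 1 `COc1ccc(C2=NN(c3ccccc3)C(c3ccc(C)cc3)C2S(=O)(=O)CC2=NCCO2)cc1`: 67.7% in a functional assay, tested at 100 ug/mL; a higher number here means a stronger effect of the compound at the concentration tested, a lower number a weaker effect
Compound 2 `COc1ccc(C2=NN(c3ccccc3)C(c3ccc(C)cc3)C2S(=O)(=O)CC2=NCCS2)cc1`: 47.9%
Compound 3 `COc1ccc(-c2noc(-c3ccc(C)cc3)c2S(=O)(=O)CC2=NCCS2)cc1`: "not active" (no number reported), with no number

Compounds 1 and 2 share one core, while compound 3 has another; the difference between the two cores is not broken down here. Within the first core, a group of 5 heavy atoms (3 carbon, 1 nitrogen, 1 oxygen; one five-membered non-aromatic ring with 2 hetero atoms) in place of a group of 5 heavy atoms (3 carbon, 1 nitrogen, 1 sulfur; one five-membered non-aromatic ring with 2 hetero atoms), on a saturated chain carbon bound to a sulfonyl sulfur produced a number 19.8 percentage points higher from compound 2 to compound 1 (beyond the scatter). Compound 4 `COc1ccc(-c2noc(-c3ccc(C)cc3)c2S(=O)(=O)CC2=NCCO2)cc1` carries the same change on the core of compound 3: a group of 5 heavy atoms (3 carbon, 1 nitrogen, 1 oxygen; one five-membered non-aromatic ring with 2 hetero atoms) in place of a group of 5 heavy atoms (3 carbon, 1 nitrogen, 1 sulfur; one five-membered non-aromatic ring with 2 hetero atoms), on a saturated chain carbon bound to a sulfonyl sulfur. Compound 3 gave no number in this assay, only "not active" (no number reported). The starting point for compound 4 is thus only known to be weak. If the change carries over with the size of a number 19.8 percentage points higher from compound 2 to compound 1 (beyond the scatter), compound 4 should reach a modest effect at best. Compound 4 is therefore expected to give about 20%, somewhere between 0% and 45%, and it may again be reported only as not active.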

Compound 4, a percentage reported as activity, at one concentration (the size of the read-out at that concentration, not a potency): 77.1%
Estimate against measurement, compound 4: 57.1 percentage points below; measured number outside the range, above it.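

Compound 3 has no number, so no size can be read for the step from it to compound 4. Nothing measured here shows why compound 4 reaches its value, and that remains open.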